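The compounds below may be only part of what the source reports. "The series", "measured", "known", "first", "only" and "open" are said of these compounds alone.

In a functional assay on MDA-MB-231 cells (Homo sapiens) for antiproliferative activity, read by MTT assay, with a stated time of 24 h (on this read-out lower numbers stand for stronger inhibition and higher numbers for weaker inhibition), compound 1 `O=C(NNc1cccc(Cl)c1)c1ccc(NS(=O)(=O)c2cnc(O)nc2O)cc1` gives 17400 nM. Compound 2 `O=C(NNc1ccccc1Cl)c1ccccc1NS(=O)(=O)c1cnc(O)nc1O` gives 18900 nM, which lies within the usual scatter of the value for compound 1, so neither compound can be ranked ahead of the other. Compound 3 `O=C(NNC(=O)c1cccc(Cl)c1)c1ccc(NS(=O)(=O)c2cnc(O)nc2O)cc1` has not yet been measured. It departs from compound 1 at a single place, with (3-chlorophenyl)carbonyl in place of 3-chlorophenyl on an amine nitrogen. Among the compounds with values here, no measured pair carries this change, so the data offer no direct guide to its effect. In this assay, no step beyond the scatter is therefore expected, only a slight lean toward weaker inhibition, and the estimated step is a 1.3-fold higher number from compound 1 to compound 3 (0.10 log units; within the scatter). For compound 3 the expected value is 22000 nM, with an estimated range from 9000 nM to 55000 nM.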

Compound 3, half-maximal inhibitory concentration: 4160 nM
The estimate for compound 3 lay 5.3-fold (0.72 log units) above the measured number; the measured number lies below the stated range.
By their numbers in this assay, from the lowest: compound 3; then compounds 1 and 2 (each within the scatter of the next).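

Within the data shown here, compound 1 and compound 3 form the first pair in this assay that differs in only one place, and they show that the group on the amine nitrogen, whose other neighbour is an amide-type nitrogen, can change the read-out. Placing (3-chlorophenyl)carbonyl there instead of 3-chlorophenyl gives a 4.2-fold lower number from compound 1 to compound 3 (0.62 log units; beyond the scatter), a modest step beyond the scatter, with stronger inhibition. The 3-chlorophenyl ring remains in compound 3, now attached through a carbonyl, but nothing available explains the gain.

This single pair leaves open whether the gain needs the aromatic ring, which an acetyl group at the same nitrogen would test. It also leaves open whether the chlorine contributes, which an unsubstituted benzoyl group would test.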